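Lengthening the chain of a cyanoguanidine-bearing pyridazinone series

This account rests on a few compounds, and the source may have more. Where it says the series, first, only, none or still open, it means among the compounds named here.

Compound 1 `N#CNC(=N)NCCCCCn1nc(-c2ccccc2)ccc1=O`: in a functional assay on the whole organism with Rattus norvegicus as the target, at a dose of 100 mg/kg (a higher number here means more inhibition at the dose given (going by the name of the read-out), a lower number less inhibition), compound 1 gives 31%
Compound 2 `CN(C)/C(=N/CCCCCn1nc(-c2ccccc2)ccc1=O)NC#N`: in this assay compound 2 gives 63.9%

Among the compounds with values here, compound 2 stands highest of the two numbers so far; its nearest neighbour is compound 1, with a step of a number 32.9 percentage points higher from compound 1 to compound 2 (beyond the scatter), beyond the scatter. Compound 3 `CN(C)/C(=N/CCCCCCn1nc(-c2ccccc2)ccc1=O)NC#N` is not yet measured. It differs from compound 2 as follows: a group of 9 heavy atoms (5 carbon, 4 nitrogen; no ring) in place of a group of 8 heavy atoms (4 carbon, 4 nitrogen; no ring), on a saturated chain carbon, five bonds along the chain from an aromatic nitrogen.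

Within the data shown here, only one measured step exists, and it concerns a different change, the exchange of the terminal group on the same chain carbon rather than the size of the chain itself. Among the measured compounds shown here, no measured step therefore bears directly on the move from compound 2 to compound 3. Without a precedent for this kind of change, the expected step in this assay is none beyond the scatter, and the estimated step is a number 3.9 percentage points lower from compound 2 to compound 3 (within the scatter). For compound 3 the estimated result is 60%, within 35% to 80%.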

Compound 3, a percentage reported as inhibition, in the whole organism at one dose (the size of the read-out at that dose, not a potency): 58.4%
Compound 3: middle estimate off by 1.6 percentage points, on the high side; the measured number falls inside the stated range.
By their numbers in this assay, from the lowest: compound 1; then compounds 3 and 2 (each within the scatter of the next).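

In this assay, the chain now has a reading of its own: the group of 9 heavy atoms in place of the group of 8 heavy atoms gives a number 5.5 percentage points lower from compound 2 to compound 3 (within the scatter), so at this position the added chain carbon leaves the number inside the usual scatter. Set against compound 1, the same group gives a number 27.4 percentage points higher from compound 1 to compound 3 (beyond the scatter), so the separation from compound 1 seen with compound 2 also appears with compound 3. No evidence at hand bears on these results.

The compounds shown leave open whether a longer chain or a shorter one would still stay within the scatter of compound 2. They also leave open how an amine or a carboxylic acid would read in place of the terminal group at the end of the chain.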